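Dropping the Nitrile from Compound 1

The compounds below may be only part of what the source reports. "The series", "measured", "known", "first", "only" and "open" are said of these compounds alone.

Compound 1, `CN(C)/N=N/c1ccccc1C(=O)/N=N/C(=O)CC#N`, in a physicochemical assay for lipophilicity (on this read-out higher numbers stand for higher lipophilicity and lower numbers for lower lipophilicity), gives 1.44.
Compound 2, `CN(C)/N=N/c1n[nH]cc1C(N)=O`, in this assay gives -0.12.
Compound 3, `CCCCCCCCN(C)/N=N/c1nc[nH]c1C(N)=O`, in this assay gives 3.2.

Among these three values compound 1 stands second highest: compound 2 lies lower and compound 3 lies higher, both gaps beyond the usual scatter of the measurement. Compound 4, `CC(=O)/N=N/C(=O)c1ccccc1/N=N/N(C)C`, differs from compound 1 in one place: hydrogen in place of cyano on a saturated chain carbon bound to a carbonyl carbon. Among the measured compounds shown here, no measured pair in this set shows this change, so the size of the step rests on the structural change alone. Removing a nitrile and leaving hydrogen is expected to raise the read-out modestly, so the step from compound 1 to compound 4 is estimated as a number 0.46 log units higher from compound 1 to compound 4 (beyond the scatter), beyond the scatter but not by much. Compound 4 is therefore expected to give 1.9, in the range 1.4 to 2.5.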

Compound 4, partition coefficient: 1.49
For compound 4 the middle estimate is 0.41 log units above the measured one; measured number inside the range.
By their numbers in this assay, from the lowest: compound 2; then compounds 1 and 4 (each within the scatter of the next); then compound 3.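

In this assay, hydrogen in place of cyano on a saturated chain carbon bound to a carbonyl carbon comes out as a number 0.05 log units higher from compound 1 to compound 4 (within the scatter). Among the compounds shown here, at this position, then, the read-out does not separate the nitrile from hydrogen, something the earlier compounds could not show, since none of them differed from another in just one place.

As far as these compounds go, whether an amine, a carboxylic acid or a longer chain at this place would also leave the read-out unmoved stays open. No accompanying measurement offers a reason for this result.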